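The source may report more compounds than this note shows. Statements on the series, on what has been measured and on what is new or still open speak of the compounds shown alone.

Working notes on the series

The series shares one core, seen in compound 2 `COc1cc2c(Oc3ccc(NC(=O)c4nnn(-c5ccc(F)cc5)c4C(F)(F)F)cc3F)ccnc2cc1OCCCN1CCCCC1` and compound 3 `COc1cc2c(Oc3ccc(NC(=O)c4nnn(-c5ccc(F)cc5)c4C(F)(F)F)cc3F)ccnc2cc1OCCCN1CCC(C)CC1`. In a functional assay on U-87MG ATCC cells (Homo sapiens) for cytotoxicity, read by MTT assay, with a stated time of 72 h (on this read-out lower numbers stand for stronger inhibition and higher numbers for weaker inhibition), compound 2 gives 1100 nM, and in the same assay compound 3 gives 800 nM. Among the measured compounds shown here, the step of a 1.4-fold lower number from compound 2 to compound 3 (0.14 log units; within the scatter) is the only single-point change with numbers on both sides. Compound 1 `COc1cc2c(Oc3ccc(NC(=O)c4nnn(-c5ccc(C)cc5)c4C(F)(F)F)cc3F)ccnc2cc1OCCCN1CCCC1` carries the methyl-bearing aryl together with a smaller saturated amine ring; in this assay compound 1 gives "not determined" (no result reported), so it adds no number. On the values shown, compound 3 holds the lowest of the two reported numbers, and compound 2 sits within the scatter of it, so no order between the two is claimed.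

Compound 4 `COc1cc2c(Oc3ccc(NC(=O)c4nnn(-c5ccc(C)cc5)c4C(F)(F)F)cc3F)ccnc2cc1OCCCN1CCC(C)CC1` differs from compound 3 by methyl in place of fluoro on an aromatic carbon. For the measured compounds named here, no measured step bears on this change: the one step on record concerns the saturated ring, and compound 1, the only other entry with the methyl, has no result. With nothing to set a direction, the expectation is a step no larger than the scatter, in either direction. The expected step is no change at the digits printed from compound 3 to compound 4 (within the scatter). Compound 4 is therefore estimated at 800 nM in this assay, with a range from 350 nM to 1800 nM.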

Compound 4, half-maximal inhibitory concentration: 2800 nM
Compound 4: the middle estimate sits 3.5-fold (0.54 log units) below what was measured; measured number above the stated range.
By their numbers in this assay, from the lowest: compounds 3 and 2 (each within the scatter of the next); then compound 4.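

Among the compounds shown here, the change from 4-fluorophenyl to 4-methylphenyl, on an aromatic carbon para to a large group, gives a 3.5-fold higher number from compound 3 to compound 4 (0.54 log units; beyond the scatter) in this assay and is the first single-point change to lie beyond the scatter; the only earlier step, on a saturated ring carbon, is a 1.4-fold lower number from compound 2 to compound 3 (0.14 log units; within the scatter) and stays within it. The exchange is one heavy atom for one heavy atom, with no ring, hydrogen-bond donor, hydrogen-bond acceptor or net charge entering or leaving, so a change this small in those counts can still register at this position, with the amine ring of compound 3 held fixed. The data shown offer no measurement that accounts for the direction of this step.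

As far as these compounds go, whether the step carries over to other saturated amine rings stays open, since the one other methyl-bearing entry, compound 1, gives "not determined" (no result reported) in this assay and so offers no comparison. The compounds shown also leave open where other groups at this position, such as chlorine, methoxy or a nitrile, would fall relative to fluoro and methyl.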